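Formyl for Hydroxymethyl in a Weakly Active Series

The source may report more compounds than this note shows. Statements on the series, on what has been measured and on what is new or still open speak of the compounds shown alone.

Compound 1 `Cn1c(Cc2nn(CCC=O)c(=O)c3ccccc23)nnc1SCC(=O)Nc1ccc(Cl)cc1Cl` carries a formyl group, and in an assay on 32D cells for inhibition of interleukin-15 (Mus musculus), read by resazurin assay, with stated times of 30 min and 2.5 days, in the presence of a further agent that is not named here (a lower number here means a stronger inhibitor, a higher number a weaker inhibitor), compound 1 gives 30000 nM. Compound 2 `Cn1c(Cc2nn(CCCO)c(=O)c3ccccc23)nnc1SCC(=O)Nc1ccc(Cl)cc1Cl` carries a hydroxymethyl group at the same place. In this assay compound 2 gives only a limit, > 30000 nM, meaning the assay reports no number for it. The two differ by formyl in place of hydroxymethyl on a saturated chain carbon, two bonds along the chain from an aromatic nitrogen. The measured step of a number no higher from compound 2 to compound 1 (the limit leaves the size open) gives no readable size; this rests on (the limit of > 30000 nM in this assay, at which 2 of the 3 values shown sit).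

Compound 3 `Cn1c(Cc2nn(CCCO)c(=O)c3ccccc23)nnc1SCCCCCCCC(=O)Nc1ccc(Cl)cc1Cl` carries the hydroxymethyl group of compound 2 on a different core, and the difference between the two cores is not broken down here. In this assay compound 3 gives only a limit, > 30000 nM. Compound 4 `Cn1c(Cc2nn(CCC=O)c(=O)c3ccccc23)nnc1SCCCCCCCC(=O)Nc1ccc(Cl)cc1Cl` has not yet been measured. It differs from compound 3 by formyl in place of hydroxymethyl on a saturated chain carbon, two bonds along the chain from an aromatic nitrogen, which is the same change as that made from compound 2 to compound 1, at a place described in the same words.

Within the data shown here, for compound 4 in this assay, a step of a number no higher from compound 3 to compound 4 (the limit leaves the size open) is expected, because the earlier step of a number no higher from compound 2 to compound 1 (the limit leaves the size open) left its size open and shows only that the number did not rise. Compound 4 is therefore expected to give 30000 nM, with a range from 10000 nM to 100000 nM, and the assay may well return only a limit for compound 4.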

Compound 4, half-maximal inhibitory concentration: 8900 nM
Compound 4: middle estimate off by 3.4-fold (0.53 log units), on the high side; measured number below the stated range.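

In this assay the change from hydroxymethyl to formyl on the core of compound 3 gives an at least 3.3-fold lower number from compound 3 to compound 4 (0.52 log units; beyond the scatter), so on this core the formyl compound is the stronger inhibitor by more than the usual scatter. On the core of compound 1 the same change did not raise the number, which points the same way, but the size of that earlier step cannot be read, so this series does not show whether the change carries over from one core to the other with the same size: the same change on two cores in this assay, a number no higher (the limit leaves the size open) from compound 2 to compound 1 and an at least 3.3-fold lower number (0.52 log units; beyond the scatter) from compound 3 to compound 4; the limit leaves it open whether they differ. Both hydroxymethyl compounds stand at a limit, which leaves the true size of each step unknown and supports no rule beyond these two pairs: the limit of > 30000 nM in this assay, at which 2 of the 4 values shown sit.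

The compounds shown leave open whether the lower number belongs to the formyl group in particular, or whether another group at this place, such as a carboxylic acid or an amine, would do the same or better. They also leave open what happens to the step when the formyl group sits on a longer chain, and whether any such change would bring this weakly active series to much lower numbers.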